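Amino to methylcarbamoyl on the ring-nitrogen carbonyl

The source may hold more compounds than are shown below. What is called first, only, known or untested is meant among the compounds shown, and "the series" means these compounds.

Three compounds with the shared core of compound 1 `CC(=O)NCC(=O)N1CC[C@H](C(=O)N(C)Cc2cc(C(F)(F)F)cc(C(F)(F)F)c2)[C@@H](c2ccc(F)cc2C)C1` differ only in the group on the carbonyl carbon attached to the amide-type nitrogen in the ring. In an assay on IM-9 cells for displacement of a labelled ligand from Substance-P receptor (Homo sapiens), read by scintillation counting, with a stated time of 30 min (on this read-out higher numbers stand for weaker inhibition and lower numbers for stronger inhibition), compound 1 gives 0.043 nM. Compound 2 `CNC(=O)N1CC[C@H](C(=O)N(C)Cc2cc(C(F)(F)F)cc(C(F)(F)F)c2)[C@@H](c2ccc(F)cc2C)C1` gives 0.048 nM in this assay, and compound 3 `Cc1cc(F)ccc1[C@H]1CN(C(N)=O)CC[C@@H]1C(=O)N(C)Cc1cc(C(F)(F)F)cc(C(F)(F)F)c1` gives 0.035 nM. The steps are a 1.1-fold higher number from compound 1 to compound 2 (0.05 log units; within the scatter), a 1.2-fold lower number from compound 1 to compound 3 (0.09 log units; within the scatter) and a 1.4-fold lower number from compound 2 to compound 3 (0.14 log units; within the scatter). Compound 3 thus carries the lowest of the three numbers, but its gaps to compound 1 and compound 2 are both within the scatter, so no order among the three can be read.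

Compound 4 `CNC(=O)C(=O)N1CC[C@H](C(=O)N(C)Cc2cc(C(F)(F)F)cc(C(F)(F)F)c2)[C@@H](c2ccc(F)cc2C)C1` is not yet measured. It differs from compound 3 by methylcarbamoyl in place of amino on a carbonyl carbon. Within the data shown here, the steps that bear on this position are those from compound 1 to compound 3 and from compound 2 to compound 3, both within the scatter, so changes here have so far left this assay unmoved. Compound 4 is therefore expected to stay close to compound 3, with the step of a 1.4-fold higher number from compound 3 to compound 4 (0.15 log units; within the scatter) meaning no change beyond the scatter. The estimate for compound 4 in this assay is 0.05 nM, expected to fall between 0.02 nM and 0.15 nM.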

Compound 4, half-maximal inhibitory concentration: 0.11 nM
For compound 4 the middle estimate is 2.2-fold (0.34 log units) below the measured one, and the stated range covers the measured number.
By their numbers in this assay, from the lowest: compounds 3, 1 and 2 (each within the scatter of the next); then compound 4.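

In this assay, among these compounds, this position, quiet until now, gives a readable response for the first time: methylcarbamoyl on the carbonyl carbon yields a 3.1-fold higher number from compound 3 to compound 4 (0.50 log units; beyond the scatter), a 2.3-fold higher number from compound 2 to compound 4 (0.36 log units; beyond the scatter) and a 2.6-fold higher number from compound 1 to compound 4 (0.41 log units; beyond the scatter), so compound 4 stands apart from the other three, all of which lie within the scatter of one another, though each step is only modest. A further carbonyl in the group is not enough on its own to produce this separation, as acetamidomethyl in compound 1 also carries one and stays within the scatter of amino in compound 3. No available measurement accounts for the shift.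

The compounds shown do not separate the contribution of the methyl in methylcarbamoyl from that of the carbonyl it adds, and a plain carbamoyl or a dimethylcarbamoyl on the same carbonyl carbon would bear directly on that. As far as these compounds go, whether the higher number persists or grows with a longer chain on the carbamoyl nitrogen, or with a carboxylic acid in place of the methylcarbamoyl, also remains open.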